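Replacing a Benzyl Ether on a Shared Core

The source may report more compounds than this note shows. Statements on the series, on what has been measured and on what is new or still open speak of the compounds shown alone.

Two compounds share a core and differ only in the group carried on a saturated chain carbon bound to an oxygen on a saturated carbon. Compound 1 `Cc1nn(-c2ncnc3nc[nH]c23)c2c1C(OCc1ccccc1F)CC(=O)N2` gives 78 nM in a functional assay on HEK293 cells for agonist activity at G-protein coupled receptor 39 (Homo sapiens), read by scintillation proximity assay and inositol phosphate accumulation, with a stated time of 75 min; a lower number here means that less compound is needed, a higher number that more compound is needed for the effect. Compound 2 `Cc1nn(-c2ncnc3nc[nH]c23)c2c1C(OCCc1ccccc1)CC(=O)N2` gives 40 nM in this assay. Among the compounds with values here, the change a 2.0-fold lower number from compound 1 to compound 2 (0.29 log units; within the scatter) is the only measured step, and compound 2 holds the lowest of the two numbers, with compound 1 the nearest.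

Compound 3 `Cc1nn(-c2ncnc3nc[nH]c23)c2c1C(OCc1cc(F)cc3c1OCOC3)CC(=O)N2` carries the change (a group of 11 heavy atoms (8 carbon, 2 oxygen, 1 fluorine; one six-membered non-aromatic ring with 2 hetero atoms, one six-membered aromatic ring of carbon only) in place of a group of 7 heavy atoms (7 carbon; one six-membered aromatic ring of carbon only), on a saturated chain carbon bound to an oxygen on a saturated carbon). Within the data shown here, the single measured step at this position stayed within the scatter, so the numbers so far give no sign that a swap at this place moves the read-out strongly in either direction; the new group has not been tested in any form here, so its effect is unknown. The expectation for compound 3 is therefore a number close to that of compound 2, with the step of a 1.3-fold higher number from compound 2 to compound 3 (0.10 log units; within the scatter) lying within the scatter. Compound 3 is estimated at 50 nM in this assay, within a range from 15 nM to 170 nM.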

Compound 3, half-maximal effective concentration: 30 nM
Compound 3: middle estimate off by 1.7-fold (0.22 log units), on the high side, within the range that was stated.
By their numbers in this assay, from the lowest: compounds 3, 2 and 1 (each within the scatter of the next, the first and the last beyond it).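

Set against benzyl, the group of 11 heavy atoms gives a 1.3-fold lower number from compound 2 to compound 3 (0.12 log units; within the scatter) in this assay, so this place accepts a group with one six-membered non-aromatic ring with 2 hetero atoms, and 2 hydrogen-bond acceptors, with no change that can be told from the usual scatter. Set against the group of compound 1, which has 7 heavy atoms including 1 fluorine, the same group gives a 2.6-fold lower number from compound 1 to compound 3 (0.41 log units; beyond the scatter), the first step at this place to lie beyond the scatter, although it is only modest. Nothing measured here offers an explanation for either step.

The compounds shown leave open which part of the new group counts, the fluorine or the non-aromatic ring, as the two enter together and neither is seen alone in this series. Also open, going by these compounds, is how a group of a different kind at this place, such as an amine or a carboxylic acid, would read in this assay, and whether the shared core would keep its number in the same range with it.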